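Adding a methoxy group to the core of compound 1

The compounds below may be only part of what the source reports. "The series", "measured", "known", "first", "only" and "open" are said of these compounds alone.

Measured compounds:
compound 1, `COc1ccc(-c2coc3cc(OCC=C(C)C)ccc3c2=O)cc1`, 45200 nM in a functional assay on BV-2 cells (Mus musculus) for inhibition; on this read-out higher numbers stand for weaker inhibition and lower numbers for stronger inhibition
compound 2, `COc1cc(-c2coc3cc(O)ccc3c2=O)cc(OC)c1O`, > 50000 nM
compound 3, `COc1ccc(-c2coc3cc(OCC=C(C)C)ccc3c2=O)cc1OC`, 36900 nM

Compound 1 gives the highest of the two numbers that this assay reports. Its nearest neighbour is compound 3, reached by a 1.2-fold lower number from compound 1 to compound 3 (0.09 log units; within the scatter). Compound 2 does not give a number at all; its value is a limit of this assay, and the limit of > 50000 nM in this assay, at which 1 of the 3 values shown sits, describes where that limit sits.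

The compound not yet measured is compound 4, `COc1ccc(-c2coc3c(OC)c(OCC=C(C)C)ccc3c2=O)cc1`. It differs from compound 1 in one place: methoxy in place of hydrogen on an aromatic carbon. For the measured compounds named here, the only measured step of the same kind is the one from compound 1 to compound 3, where a methoxy group also entered in place of hydrogen on an aromatic carbon, though on the other ring of the shared core; that step stayed within the scatter. On this basis the step into compound 4 is also expected to stay small, with no direction beyond the scatter. The estimate for compound 4 is therefore 42000 nM, with a range from 20000 nM to 90000 nM, which means an expected change of a 1.1-fold lower number from compound 1 to compound 4 (0.03 log units; within the scatter).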

Compound 4, half-maximal inhibitory concentration: 35700 nM
Compound 4: the middle estimate sits 1.2-fold (0.07 log units) above what was measured; the measured number falls inside the stated range.
By their numbers in this assay, from the lowest: compounds 4, 3 and 1 (each within the scatter of the next). At a limit, above all of these: compound 2.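

In this assay the result shows that a methoxy group can enter on the aromatic carbon ortho to the (3-methylbut-2-en-1-yl)oxy group with only a step of a 1.3-fold lower number from compound 1 to compound 4 (0.10 log units; within the scatter) on the number, so this position of the shared core now has a reading of its own. Set beside the earlier step of a 1.2-fold lower number from compound 1 to compound 3 (0.09 log units; within the scatter) on the other ring of the shared core, it means that methoxy in place of hydrogen has been read at two places, and neither step leaves the scatter, so no compound among those shown goes against this small pattern. The compounds shown hold no measurement that accounts for this result.

For the compounds shown here, what remains open is whether any other group on this same aromatic carbon, such as an amine, a carboxylic acid or a fluorine atom, would move the number beyond the scatter, since methoxy is the only group read here. As far as these compounds go, it is also open whether a longer chain in place of the (3-methylbut-2-en-1-yl)oxy group would change the number, with or without the methoxy group beside the data for compound 4.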